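Thiophen-3-yl in place of benzyl on compound 1

This account rests on a few compounds, and the source may have more. Where it says the series, first, only, none or still open, it means among the compounds named here.

compound 1 `C[C@@H](NCc1ccc(OCCc2ccccc2)cc1)C(N)=O` gives 24.9 mg/kg
compound 2 `C[C@@H](NCc1ccc(CNc2ccccc2)cc1)C(N)=O` gives 119 mg/kg

In a functional assay on the whole organism with Mus musculus as the target (on this read-out lower numbers stand for an effect already at smaller amounts and higher numbers for an effect only at larger amounts of compound), compound 1 at 24.9 mg/kg holds the lower of the two numbers, and compound 2 lies above it by a gap beyond the scatter. Compound 3 `C[C@@H](NCc1ccc(OCc2ccsc2)cc1)C(N)=O` has thiophen-3-yl in place of benzyl on a saturated chain carbon bound to an oxygen on an aromatic ring. Among the compounds with values here, no measured pair isolates this change. A small drift towards a lower number in this assay is expected, with no step beyond the scatter. The expected step is a 1.6-fold lower number from compound 1 to compound 3 (0.19 log units; within the scatter) on this estimate. For compound 3 the estimated value is 16 mg/kg within an expected range of 6 mg/kg to 42 mg/kg for now.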

Compound 3, dose for half-maximal effect: 114 mg/kg
The estimate for compound 3 lay 7.1-fold (0.85 log units) below the measured number; measured number above the stated range.
By their numbers in this assay, from the lowest: compound 1; then compounds 3 and 2 (each within the scatter of the next).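

In this assay, within the data shown here, thiophen-3-yl in place of benzyl on a saturated chain carbon bound to an oxygen on an aromatic ring gives a 4.6-fold higher number from compound 1 to compound 3 (0.66 log units; beyond the scatter) as the only single-place step. This position is therefore not indifferent to the group it carries, and benzyl holds the lower number of this pair. Nothing at hand gives a cause for this step.

One pair cannot separate the effect of ring size from that of the ring sulfur. Pyridin-3-yl at this place would show how a six-membered aromatic ring with a hetero atom behaves.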